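This account rests on a few compounds, and the source may have more. Where it says the series, first, only, none or still open, it means among the compounds named here.

Compound 2, `C[Se]/C(=N\C(=O)c1ccco1)NC(=O)c1ccco1`, is examined in a functional assay on HepG2 cells (Homo sapiens) for cytotoxicity, read by MTT assay, with a stated time of 72 h; on this read-out higher numbers stand for lower toxicity in this test and lower numbers for higher toxicity in this test. In this assay compound 2 reaches only the limit of > 100000 nM, which is a limit and not a number. Compound 1, `CS/C(=N\C(=O)c1ccno1)NC(=O)c1ccno1`, likewise reaches only the limit of > 100000 nM in this assay. Compound 3, `O=C(/N=C(/NC(=O)c1csc([N+](=O)[O-])c1)[Se]Cc1ccccc1)c1csc([N+](=O)[O-])c1`, gives 91600 nM in this assay. Among the measured compounds shown here, compound 2 thus stands at the limit of > 100000 nM in this assay, at which 2 of the 3 values shown sit, and the one numbered value shown, that of compound 3, lies close to that same limit.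

The step from compound 2 leads to compound 4, `O=C(/N=C(/NC(=O)c1ccco1)[Se]Cc1ccccc1)c1ccco1`. The change is phenyl in place of hydrogen on a saturated chain carbon bound to a selenium atom. No pair of measured compounds differs in just this one place, so the size of this step is not known from the data shown. Compound 3 carries the same benzyl group on a saturated chain carbon bound to a selenium atom and gives 91600 nM in this assay. The estimated step, a number no higher from compound 2 to compound 4 (the limit leaves the size open), is expected to stay within the usual scatter, in no clear direction. Compound 4 is therefore expected to give about 100000 nM in this assay, between 50000 nM and 200000 nM, with a fair chance that only a limit is reported again.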

Compound 4, concentration lethal to 50% of the cells: 76500 nM
Compound 4: the middle estimate sits 1.3-fold (0.12 log units) above what was measured; the measured number falls inside the stated range.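

In this assay, among the compounds shown here, the change from methyl to benzyl on this position turns a limit into a number, so a step can be stated for the first time, though only as a floor: an at least 1.3-fold lower number from compound 2 to compound 4 (0.11 log units; that floor lies within the scatter). As far as these compounds go, the true size of the step remains unknown, since its starting point is a limit and not a number: the limit of > 100000 nM in this assay, at which 2 of the 4 values shown sit. The data therefore show no step beyond the scatter for phenyl in place of hydrogen at this place, but they do not exclude a larger one.

From the compounds shown here alone, what remains open is how the number would respond to a longer chain at this place, or to an amine or a carboxylic acid on the phenyl group. Going by these compounds, it is equally open what a sulfur atom in place of the selenium atom would do in compound 4.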